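The compounds below may be only part of what the source reports. "The series", "measured", "known", "first", "only" and "open" are said of these compounds alone.

Compound 2 `O=C1NC(=S)S/C1=C\C=C\c1ccccc1OCc1ccccc1` gives 49.5% in an assay on isolated protein for inhibition of protein tyrosine phosphatase type IVA 3 (Homo sapiens), tested at 5 ug/mL; a higher number here means more inhibition at the concentration tested (going by the name of the read-out), a lower number less inhibition. Of the two numbers in hand, compound 2 and compound 1 `O=C1NC(=S)S/C1=C\C=C\c1ccccc1OCc1ccccc1C(F)(F)F`, which gives 40.8% in this assay, lie within the scatter of each other: a number 8.7 percentage points higher from compound 1 to compound 2 (within the scatter). Compound 3 `COc1ccccc1/C=C/C=C1\SC(=S)NC1=O` differs from compound 2 by hydrogen in place of phenyl on a saturated chain carbon bound to an oxygen on an aromatic ring. Within the data shown here, the one measured step, a number 8.7 percentage points higher from compound 1 to compound 2 (within the scatter), concerns only a substituent on the benzyl group and says nothing about its removal, so no direction can be read from it. The expected step of a number 11.5 percentage points lower from compound 2 to compound 3 (beyond the scatter) is therefore taken as small and uncertain. Compound 3 is estimated at 38%, in a range from 12% to 62%.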

Compound 3, a percentage reported as inhibition, at one concentration (the size of the read-out at that concentration, not a potency): 41.7%
Estimate against measurement, compound 3: 3.7 percentage points below; the measured number falls inside the stated range.
By their numbers in this assay, from the lowest: compounds 1, 3 and 2 (each within the scatter of the next).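

Going from benzyloxy to methoxy gives a number 7.8 percentage points lower from compound 2 to compound 3 (within the scatter) in this assay, so the phenyl on this saturated chain carbon is not needed for a reading of this size. The two compounds cannot be ordered, and so far this position accepts either benzyl or methyl on the oxygen. Nothing available explains this outcome.

Still open, on these data alone, is whether a longer chain on this oxygen, or one ending in an amine or a carboxylic acid, would read differently. A free hydroxyl in place of methoxy is also untested in the compounds shown.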